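Changing the group on the ring nitrogen of compound 1

This account rests on a few compounds, and the source may have more. Where it says the series, first, only, none or still open, it means among the compounds named here.

Compound 1 `CCOC(=O)c1c(C)nc(-c2cccc(C#N)c2)n1C` is the reference point. In a functional assay on a cell-free system (plasma, Oryctolagus cuniculus) for inhibition, with stated times of 5 min, 1 min and 6 min (on this read-out lower numbers stand for stronger inhibition and higher numbers for weaker inhibition), compound 1 gives 22100 nM, the highest of the two numbers at hand, with compound 2 `CCOC(=O)c1c(C)nc(-c2cccc(C#N)c2)n1OC(C)C` as its nearest neighbour at 6740 nM. Compound 3 `CCOC(=O)c1c(C)nc(-c2cccc(C#N)c2)n1OCC(N)=O` reaches only the limit of this assay, reported as > 30000 nM. The measured steps are a 3.3-fold lower number from compound 1 to compound 2 (0.52 log units; beyond the scatter), an at least 1.3-fold higher number from compound 1 to compound 3 (0.13 log units; that floor lies within the scatter) and an at least 4.4-fold higher number from compound 2 to compound 3 (0.64 log units; beyond the scatter). Compound 4 `CCOC(=O)c1c(C)nc(-c2cccc(C#N)c2)n1OCc1ccc(F)cc1` has not yet been measured in this assay; it differs from compound 1 by (4-fluorobenzyl)oxy in place of methyl on an aromatic nitrogen. The step that bears on it most is a 3.3-fold lower number from compound 1 to compound 2 (0.52 log units; beyond the scatter), since both replace the methyl on the ring nitrogen with an alkoxy group, whereas an at least 1.3-fold higher number from compound 1 to compound 3 (0.13 log units; that floor lies within the scatter) and an at least 4.4-fold higher number from compound 2 to compound 3 (0.64 log units; beyond the scatter) show the carbamoylmethoxy group moving the number the other way, to the limit. Compound 4 is therefore expected to give a lower number than compound 1 in this assay, with the step from compound 1 estimated as a 5.5-fold lower number from compound 1 to compound 4 (0.74 log units; beyond the scatter). For compound 4 the estimated value in this assay is 4000 nM, within a range from 1000 nM to 15000 nM.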

Compound 4, half-maximal inhibitory concentration: 5880 nM
The estimate for compound 4 lay 1.5-fold (0.17 log units) below the measured number; the range from low to high includes it.
By their numbers in this assay, from the lowest: compounds 4 and 2 (each within the scatter of the next); then compound 1. At a limit, above all of these: compound 3.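

The (4-fluorobenzyl)oxy group on the ring nitrogen brings one six-membered aromatic ring of carbon only, and in this assay it gives a 3.8-fold lower number from compound 1 to compound 4 (0.58 log units; beyond the scatter), while exchanging isopropyl for 4-fluorobenzyl on the oxygen gives a 1.1-fold lower number from compound 2 to compound 4 (0.06 log units; within the scatter), so these two groups cannot be told apart here. Placing 4-fluorophenyl where the carbamoyl stood on the saturated chain carbon gives an at least 5.1-fold lower number from compound 3 to compound 4 (0.70 log units; beyond the scatter), which shows that the high reading of the carbamoylmethoxy group does not hold for every group on this oxygen. Compound 3 remains a limit and not a number: the limit of > 30000 nM in this assay, at which 1 of the 4 values shown sits.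

Open, going by these compounds, is how a plain benzyl group on the oxygen would compare with 4-fluorobenzyl. Also open, on these data alone, is where a longer alkyl chain, an amine or a carboxylic acid on this oxygen would fall.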